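Swapping the Urea Substituent: From Compound 2 to Compound 3

A few compounds are considered here, and "the series" means these few. Any claim that something is new, unique, unknown or untested is made for them only; others in the source may bear on it.

Measured so far:
compound 1, `CC(C)N1CC2(CCN(C(=O)Nc3ccc(F)c(F)c3)CC2)C1c1ccc(Cl)cc1`, gives 174 nM
compound 2, `CC[C@H](C)[C@H](NC(=O)N1CCC2(CC1)C(=O)N(c1cccc(F)c1)C2c1ccc(Cl)cc1)C(=O)OC(C)C`, gives 45 nM

Both numbers come from an assay on HEK293 cells for inhibition of Voltage-dependent T-type calcium channel subunit alpha-1H (Homo sapiens), read by patch clamp, using a membrane potential dye; a higher number here means a weaker inhibitor, a lower number a stronger inhibitor. Of the two, compound 2 has the lower number; compound 1 sits higher, and that gap lies beyond the usual scatter of repeated measurements.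

Compound 3, `C[C@H](NC(=O)N1CCC2(CC1)C(=O)N(c1cccc(F)c1)C2c1ccc(Cl)cc1)c1ccccc1`, keeps the shared core of compound 2 and changes only the group on the urea nitrogen: a group of 8 heavy atoms (8 carbon; one six-membered aromatic ring of carbon only) in place of a group of 11 heavy atoms (9 carbon, 2 oxygen; no ring), on an amide-type nitrogen. Among the compounds with values here, no measured pair in this set shows what such a change does, so there is nothing to scale from. The expectation for the step from compound 2 to compound 3 is therefore no change beyond the scatter, with the estimate no change at the digits printed from compound 2 to compound 3 (within the scatter) in this assay .

Compound 3 is accordingly expected to give about 45 nM in this assay , with a likely range from 12 nM to 160 nM.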

Compound 3, half-maximal inhibitory concentration: 139 nM
For compound 3 the middle estimate is 3.1-fold (0.49 log units) below the measured one, within the range that was stated.
By their numbers in this assay, from the lowest: compound 2; then compounds 3 and 1 (each within the scatter of the next).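

Within the data shown here, this is the first pair in the set that differs in one place, and it shows that the group on this amide-type nitrogen affects the reading in this assay: 1-phenylethyl in place of the open-chain group of 11 heavy atoms gives a 3.1-fold higher number from compound 2 to compound 3 (0.49 log units; beyond the scatter). The step is modest, so a group with a six-membered aromatic ring and no oxygen still gives an inhibitor at this position, though a weaker one than compound 2. No measured data here offer a reason for the step.

On these data alone, with one pair, it remains open whether the oxygens or the chain of the departing group account for the difference, and whether the stereocentre of 1-phenylethyl plays any part. The compounds shown also leave open how a carboxylic acid or a plain benzyl group would read on this nitrogen.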